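From Dimethylamide to 4-Chlorophenyl Ester: an Untested Step

The source may hold more compounds than are shown below. What is called first, only, known or untested is meant among the compounds shown, and "the series" means these compounds.

Of the compounds shown here, two sharing a common core have been measured so far. Compound 1 `Cc1nc(C2COc3ccccc3O2)sc1C(=O)O` carries a carboxylic acid on that core. In an assay for inhibition of Caspase-8 (Homo sapiens), read by fluorescence (a higher number here means a weaker inhibitor, a lower number a stronger inhibitor), compound 1 gives > 200000 nM, which is a limit of the assay rather than a number. Compound 2 `CN(C)C(=O)c1csc(C2COc3ccccc3O2)n1` carries a dimethylamide instead. In this assay compound 2 gives > 200000 nM, again a limit rather than a number. Where compound 2 stands is therefore only (the limit of > 200000 nM in this assay, at which 2 of the 2 values shown sit), and no measured step between compounds exists from which a direction could be read.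

Compound 3 `O=C(Oc1ccc(Cl)cc1)c1csc(C2COc3ccccc3O2)n1` is not yet measured. It differs from compound 2 in one place: 4-chlorophenoxy in place of dimethylamino on a carbonyl carbon, in words 4-chlorophenoxy in place of dimethylamino on a carbonyl carbon. Within the data shown here, with no measured step to lean on, the expected movement from compound 2 to compound 3, an at least 1.3-fold lower number from compound 2 to compound 3 (0.12 log units; that floor lies within the scatter), is stated only as an expectation and could well be none beyond the scatter. For compound 3 the estimate in this assay is 150000 nM, with a range from 20000 nM to 400000 nM, and a limit rather than a number remains the likelier outcome.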

Compound 3, half-maximal inhibitory concentration: > 200000 nM
Compound 3 ended at the assay's limit; the forecaster's own chance of this, stated with the estimate: 70%; middle value at least 1.3-fold (0.12 log units) away from the limit.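

In this assay compound 3 gives > 200000 nM, which is a limit of the assay and not a number. Among these compounds, compound 2 also stands at a limit, so no step from compound 2 to compound 3 can be read. The compounds shown leave open how any change on the shared core moves the number, because none has left the limit: the limit of > 200000 nM in this assay, at which 3 of the 3 values shown sit.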